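The compounds below may be only part of what the source reports. "The series", "measured", "known", "first", "only" and "open" are said of these compounds alone.

In an ADME assay on cells (Hepatocyte, Mus musculus) for metabolic stability, read by LC-MS, with a stated time of 180 min, tested at 1 uM (on this read-out higher numbers stand for fast clearance and lower numbers for slow clearance), compound 1 `O=C(O)Cn1nc(Cc2nc3cc(Cl)c(OCC(F)F)cc3[nH]2)c2ccccc2c1=O` gives < 28.4 mL/min/kg, which is a limit of the assay and not a number. Compound 2 `O=C(O)Cc1nn(Cc2cn3cc(OCC4CC4)c(Cl)cc3n2)c2ccccc2c1=O` gives 30 mL/min/kg, the only exact clearance available so far. Compound 3 `CC(C)(C(=O)O)c1nn(Cc2cn3cc(OCC4CC4)c(Cl)cc3n2)c2ccccc2c1=O` keeps the rest of compound 2 but carries 1-carboxy-1-methylethyl in place of carboxymethyl on an aromatic carbon. For the measured compounds named here, no measured pair of compounds shows what this change does. The expected size of the change, a 1.1-fold higher number from compound 2 to compound 3 (0.04 log units; within the scatter), stays within the usual scatter, with no clear direction. For compound 3 the estimated clearance is 33 mL/min/kg, with a range of 28 mL/min/kg to 62 mL/min/kg.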

Compound 3, clearance: 317 mL/min/kg
Estimate against measurement, compound 3: 9.6-fold (0.98 log units) below; measured number outside the range, above it.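

In this assay, putting 1-carboxy-1-methylethyl in place of carboxymethyl on this aromatic carbon gives an 11-fold higher number from compound 2 to compound 3 (1.02 log units; beyond the scatter), a large step. The earlier compounds shown here offered no comparison at this position, and this pair shows that clearance can respond strongly to a single change in the group on this carbon. Nothing in the data shown explains the rise.

The compounds shown leave open where 1-carboxyethyl, or the longer chain 2-carboxyethyl, would fall. They also leave open whether the same change gives a similar step on another core.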